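Furan to methoxyphenyl swap at the saturated ring carbon

The source may report more compounds than this note shows. Statements on the series, on what has been measured and on what is new or still open speak of the compounds shown alone.

Measured so far in an ADME assay on MT2 cells (Homo sapiens) for cytotoxicity; on this read-out higher numbers stand for lower toxicity in this test and lower numbers for higher toxicity in this test:
- compound 1, `COc1cccc([C@@H]2CC(=O)C[C@H](c3ccco3)C23C(=O)OC(C)(C)OC3=O)c1OC`, gives > 111000 nM.
- compound 2, `CCOC(=O)C1=C(O)CCC2(C(=O)OC(C)(C)OC2=O)[C@H]1c1ccco1`, gives > 111000 nM.

The value of compound 1, > 111000 nM, is a limit of this assay, not a number. The value of compound 2, > 111000 nM, is likewise a limit of this assay. For the measured compounds named here, both known values therefore sit at the limit of > 111000 nM in this assay, at which 2 of the 2 values shown sit, so compound 2 stands at the top of what the test reports, with no separation from compound 1 beyond the scatter and no measured step available between the two.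

Compound 3, `CCOC(=O)C1=C(O)CCC2(C(=O)OC(C)(C)OC2=O)[C@H]1c1ccccc1OC`, is not yet measured in this assay. It differs from compound 2 by 2-methoxyphenyl in place of furan-2-yl on a saturated ring carbon.

Going by the values given here, no measured step shows what this change does to cytotoxicity here. With both known values resting at the limit, the expectation for compound 3 is no step beyond the scatter, and the step from compound 2 to compound 3 in this assay is estimated as a number no higher from compound 2 to compound 3 (the limit leaves the size open). Compound 3 is thus expected to come out near 111000 nM, in a range from 40000 nM to 250000 nM, most likely again reported only as a limit.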

Compound 3, half-maximal cytotoxic concentration: > 111000 nM
Compound 3 was reported as a limit; the forecaster's own chance of this, stated with the estimate: 75%; the middle value sits exactly at the limit.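

For the compounds shown here, no step from compound 2 to compound 3 can be read in this assay, since the values of both compounds are limits of the assay: the limit of > 111000 nM in this assay, at which 3 of the 3 values shown sit. The compounds shown leave open what 2-methoxyphenyl in place of furan-2-yl does to cytotoxicity, and at what concentration any of these compounds would reach a half-maximal cytotoxic effect.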